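Chloro to methoxy on the anilide of compound 1

The compounds below may be only part of what the source reports. "The series", "measured", "known", "first", "only" and "open" are said of these compounds alone.

In a functional assay on HCT-116 cells (Homo sapiens) for inhibition, read by colorimetric assay, with a stated time of 3 days (on this read-out lower numbers stand for stronger inhibition and higher numbers for weaker inhibition), compound 1 `O=C(CCCCCCNC(=O)C(O)(O)C(F)(F)F)Nc1ccc(Cl)cc1` gives 4230 nM, the lowest of the two numbers measured. Compound 3 `Cc1ccc(S(=O)(=O)Nc2ccc(NC(=O)CCCCCCNC(=O)C(O)(O)C(F)(F)F)cc2)cc1` gives 17200 nM, with a 4.1-fold higher number from compound 1 to compound 3 (0.61 log units; beyond the scatter). Compound 2 `O=C(CCCCCCNC(=O)C(O)(O)C(F)(F)F)Nc1ccc(C(=O)c2ccccc2)cc1` reaches only a limit of the assay, > 40000 nM (the limit of > 40000 nM in this assay, at which 1 of the 3 values shown sits). Compound 4 `COc1cccc(NC(=O)CCCCCCNC(=O)C(O)(O)C(F)(F)F)c1` has not yet been measured; it differs from compound 1 by 3-methoxyphenyl in place of 4-chlorophenyl on an amide-type nitrogen. Going by the values given here, no measured step covers this exact change: both known steps replace chloro with a larger group on an aromatic carbon, and both raise the number, one by an at least 9.4-fold higher number from compound 1 to compound 2 (0.97 log units; beyond the scatter). The group entering compound 4 is of a different kind, so only a small rise, near the edge of the scatter, is expected. For compound 4 the estimate is 7000 nM, between 2500 nM and 25000 nM, an expected step of a 1.7-fold higher number from compound 1 to compound 4 (0.22 log units; within the scatter).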

Compound 4, half-maximal inhibitory concentration: 6110 nM
For compound 4 the middle estimate is 1.1-fold (0.06 log units) above the measured one; the range from low to high includes it.
By their numbers in this assay, from the lowest: compounds 1 and 4 (each within the scatter of the next); then compound 3. At a limit, above all of these: compound 2.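

In this assay the exchange of 4-chlorophenyl for 3-methoxyphenyl on the amide-type nitrogen gives a 1.4-fold higher number from compound 1 to compound 4 (0.16 log units; within the scatter) and is thus the first change from compound 1 shown here that stays within the scatter. Compounds 2 and 3, which keep the ring attached at the same place as compound 1 and carry a larger group in place of chloro, both move beyond it. Nothing measured here gives a cause for this step. The compounds shown leave open how 3-chlorophenyl or 4-methoxyphenyl would read, so the change of group and the change of its place cannot be separated. They also leave open how an amine or a carboxylic acid on this ring would read.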